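The compounds below may be only part of what the source reports. "The series", "measured", "known", "first", "only" and "open" are said of these compounds alone.

Measured compounds:
compound 1 `O=C(CCCc1nc2ccccc2c(=O)[nH]1)N/N=C/c1cc(O)c(O)c(O)c1` gives 45000000 nM in a physicochemical assay, read by spectrophotometry, with a stated time of 15 min; on this read-out lower numbers stand for stronger inhibition and higher numbers for weaker inhibition;
compound 2 `COc1cc(/C=N/NC(=O)CCCc2nc3ccccc3c(=O)[nH]2)ccc1O` gives 280000000 nM;
compound 3 `COc1cc(/C=N/NC(=O)CCc2nc3ccccc3c(=O)[nH]2)ccc1O` gives 290000000 nM.

Compound 2 and compound 3 share the hydrazone end, and the difference between the two cores is not broken down here; their two values lie within the scatter of each other, so nothing can be said of an order between them. Compound 1 differs from compound 2 in one place, (3,4,5-trihydroxyphenyl in place of 4-hydroxy-3-methoxyphenyl on a carbon with a double bond to nitrogen), and this change gives a 6.2-fold lower number from compound 2 to compound 1 (0.79 log units; beyond the scatter).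

Compound 4 `O=C(CCc1nc2ccccc2c(=O)[nH]1)N/N=C/c1cc(O)c(O)c(O)c1` is not yet measured. It stands to compound 3 as compound 1 stands to compound 2: 3,4,5-trihydroxyphenyl in place of 4-hydroxy-3-methoxyphenyl on a carbon with a double bond to nitrogen. The place is worded the same in both pairs, so this is the same change, made on the core of compound 3 instead of the core of compound 2.

The expectation for compound 4 rests on the single step that this change has shown, from compound 2 to compound 1. Because compound 3 gives 290000000 nM and the change gave a 6.2-fold lower number from compound 2 to compound 1 (0.79 log units; beyond the scatter), the step from compound 3 to compound 4 is estimated as a 6.2-fold lower number from compound 3 to compound 4 (0.79 log units; beyond the scatter), of about the same size as the earlier one. Compound 4 is therefore expected at 47000000 nM, estimated between 20000000 nM and 110000000 nM.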

Compound 4, half-maximal inhibitory concentration: 45000000 nM
Compound 4: middle estimate off by 1.0-fold (0.02 log units), on the high side; low and high end bracket the measured number.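

Carried to the second core, the replacement of 4-hydroxy-3-methoxyphenyl by 3,4,5-trihydroxyphenyl gives a 6.4-fold lower number from compound 3 to compound 4 (0.81 log units; beyond the scatter) in this assay, of about the same size as the earlier step, a 6.2-fold lower number from compound 2 to compound 1 (0.79 log units; beyond the scatter), so the change carries over between these two cores. Going by these compounds alone, this rests on only two matched pairs in a single read-out, and it shows nothing about whether the step would hold on any other core or in any other assay. No measurement available here explains the step or its repeat on the second core.

Still open, as far as these compounds go, is whether all the hydroxy groups of 3,4,5-trihydroxyphenyl are needed for this step, or whether a 3,4-dihydroxyphenyl group or a carboxylic acid on the same carbon would give a step of similar size. Within the data shown here, also open is whether the step would persist with a longer chain than the one in compound 1.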